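The source may hold more compounds than are shown below. What is called first, only, known or untested is meant among the compounds shown, and "the series" means these compounds.

Compound 1 `Cc1nc(O)c(C#N)c(NCc2ccccn2)n1`: 180000 nM
Compound 2 `Cc1nc(O)c(C#N)c(NCc2ccncc2)n1`: 250000 nM
Compound 3 `CCNc1nc(C)nc(O)c1C#N`: 300000 nM

These three compounds were measured in a functional assay with Felis catus as the target (on this read-out lower numbers stand for an effect already at smaller amounts and higher numbers for an effect only at larger amounts of compound), and their numbers all lie within the scatter of one another. Compound 3, which carries the smallest chain of the three, therefore stands level with the other two, at 300000 nM.

Compound 4 `CCCNc1nc(C)nc(O)c1C#N` turns the ethylamino group of compound 3 into propylamino: methyl in place of hydrogen on a saturated chain carbon, two bonds along the chain from a nitrogen on an aromatic ring. This is methyl in place of hydrogen on a saturated chain carbon, two bonds along the chain from a nitrogen on an aromatic ring.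

For the measured compounds named here, no measured step makes this exact change, so the closest guide is the steps that alter what the chain carries. Replacing pyridin-2-yl with methyl gave a 1.7-fold higher number from compound 1 to compound 3 (0.22 log units; within the scatter), and replacing pyridin-4-yl with methyl gave a 1.2-fold higher number from compound 2 to compound 3 (0.08 log units; within the scatter). Exchanging the two pyridinyl groups gave a 1.4-fold higher number from compound 1 to compound 2 (0.14 log units; within the scatter). Even these larger exchanges stayed within the scatter, so the addition of a single methyl is expected to produce no step beyond it, in either direction. The expected change is a 1.2-fold lower number from compound 3 to compound 4 (0.06 log units; within the scatter). The estimated value for compound 4 is 260000 nM, with an expected range from 130000 nM to 520000 nM.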

Compound 4, half-maximal effective concentration: 17000 nM
Beside the measured number, compound 4's estimate is 15-fold (1.18 log units) above it, outside the stated range (below it).
By their numbers in this assay, from the lowest: compound 4; then compounds 1, 2 and 3 (each within the scatter of the next).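

In this assay, for the compounds shown here, the change from ethylamino to propylamino, methyl in place of hydrogen on a saturated chain carbon, gives an 18-fold lower number from compound 3 to compound 4 (1.25 log units; beyond the scatter) and is the first step in this set to lie beyond the scatter, so this position on the chain responds to a single added methyl, although the earlier exchanges among compounds 1, 2 and 3 did not move the number beyond the scatter. The propyl chain also separates compound 4 from the compounds that carry a pyridinyl group on the chain carbon, with a 15-fold lower number from compound 2 to compound 4 (1.17 log units; beyond the scatter) and an 11-fold lower number from compound 1 to compound 4 (1.02 log units; beyond the scatter) when ethyl takes the place of pyridin-4-yl and pyridin-2-yl. No evidence at hand accounts for this step.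

On these data alone, whether a butyl group or a still longer chain would lower the number further or raise it again remains open, and so does what a branched chain such as isopropyl would give on the same nitrogen. The compounds shown also leave open whether a hydroxyl group or an amine at the end of the propyl chain would keep the low number of compound 4.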